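The source may hold more compounds than are shown below. What is called first, only, known or untested is meant among the compounds shown, and "the series" means these compounds.

Measured so far:

Compound 1 `COc1ccc(-c2cc(OC)cc(C(=O)Nc3nn[nH]n3)n2)cc1` gives 60% in a functional assay on the whole organism with Rattus norvegicus as the target, at a dose of 3 mg/kg by the oral route; a lower number here means a weaker effect, a higher number a stronger effect of the compound at the dose given.
Compound 2 `CNc1ccc(-c2cc(OC)cc(C(=O)Nc3nn[nH]n3)n2)cc1` gives 79% in this assay.

Among the measured compounds shown here, compound 2 stands highest of the two numbers; its nearest neighbour is compound 1, and the one measured step, a number 19 percentage points higher from compound 1 to compound 2 (beyond the scatter), lies beyond the scatter. For the measured compounds named here, that step is the only piece of evidence at hand, and it concerns a different change: methylamino in place of methoxy on an aromatic carbon.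

Compound 3 `COc1cc(C(=O)Nc2nn[nH]n2)nc(-c2ccc(N(C)C)cc2)c1` is the next compound. It differs from compound 2 by methyl in place of hydrogen on a nitrogen on an aromatic ring. Going by the values given here, no measured pair shows this kind of change, a methyl added to a nitrogen on an aromatic ring, so the step from compound 1 to compound 2 bears on it only loosely: it tells that the region around this nitrogen tolerates alteration, but not in which direction a second methyl would move the number.

With only that to go on, the step of a number 3 percentage points lower from compound 2 to compound 3 (within the scatter) is expected to stay within the usual scatter, with the range allowing a modest fall. Compound 3 is therefore estimated at 76%, between 56% and 92%.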

Compound 3, a percentage reported as inhibition, in the whole organism at one dose (the size of the read-out at that dose, not a potency): 100%
The estimate for compound 3 lay 24 percentage points below the measured number, outside the stated range (above it).
By their numbers in this assay, from the lowest: compound 1; then compound 2; then compound 3.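

Adding a methyl to this nitrogen is not a silent change in this assay: the second methyl moves the number as clearly as the first exchange did (a number 21 percentage points higher from compound 2 to compound 3 (beyond the scatter)). The three groups on this aromatic carbon now fall into a clear order, with methoxy lowest, methylamino in the middle and dimethylamino highest, and the whole exchange of dimethylamino in place of methoxy spans a large distance (a number 40 percentage points higher from compound 1 to compound 3 (beyond the scatter)). Nothing available explains why the number climbs along this short series.

From the compounds shown here alone, it remains open how the plain amine, with no methyl on the nitrogen, would compare, and whether larger groups on this nitrogen, such as diethylamino or a pyrrolidine ring, would hold the number at the level of compound 3 (100%) or lose it. Each compound is also read at a single dose, so the order describes a stronger or weaker effect at that dose and nothing beyond it.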